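A few compounds are considered here, and "the series" means these few. Any claim that something is new, unique, unknown or untested is made for them only; others in the source may bear on it.

Measured so far:

Compound 1, `COc1ccc(C2N=C(SCc3ccc(Cl)cc3)NC(C)=C2C(=O)Nc2ccc(F)cc2)cc1OC`, gives 5.7%.
Compound 2, `COc1ccc(C2N=C(SCc3ccc(F)cc3)NC(C)=C2C(=O)Nc2ccc(F)cc2)cc1OC`, gives 6.7%.
Compound 3, `CC1=C(C(=O)Nc2ccc(F)cc2)C(c2ccc([N+](=O)[O-])cc2)N=C(SCc2ccc(Cl)cc2)N1`, gives 6.7%.

All three numbers come from a functional assay on the whole organism (artery, strain albino) with Rattus norvegicus as the target, with a stated time of 30 min, at a dose of 10 mg/kg by the oral route; on this read-out higher numbers stand for more inhibition at the one dose given (going by the name of the read-out) and lower numbers for less inhibition. Every one of them is small, so none of the three compounds shows much effect at the dose given, and the three numbers lie close together. Compound 1 and compound 2 share the same core and differ only in one place: fluoro in place of chloro on an aromatic carbon. That change gave a number 1 percentage points higher from compound 1 to compound 2 (within the scatter). Compound 1 and compound 3 differ in their cores, and the difference is 4-nitrophenyl in place of 3,4-dimethoxyphenyl on a saturated ring carbon; it gave a number 1 percentage points higher from compound 1 to compound 3 (within the scatter). Within the data shown here, no step is computed between compound 2 and compound 3; their two values are level at the digits given.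

The compound still to be measured is compound 4, `CC1=C(C(=O)Nc2ccc(F)cc2)C(c2ccc([N+](=O)[O-])cc2)N=C(SCc2ccc(F)cc2)N1`. Among the measured compounds shown here, it differs from compound 3 by fluoro in place of chloro on an aromatic carbon, which is the same change as the one from compound 1 to compound 2, made on the other core. Since the earlier change stayed within the scatter, the expected step here is a number 0.8 percentage points higher from compound 3 to compound 4 (within the scatter), resting on the measured step of a number 1 percentage points higher from compound 1 to compound 2 (within the scatter). For compound 4 in this assay the estimated value is 7.5%, expected to lie between 0% and 17%.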

Compound 4, a percentage reported as inhibition, in the whole organism at one dose (the size of the read-out at that dose, not a potency): 5.7%
For compound 4 the middle estimate is 1.8 percentage points above the measured one, within the range that was stated.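

In this assay, fluoro in place of chloro on the core of compound 3 gave a number 1 percentage points lower from compound 3 to compound 4 (within the scatter), and this agrees with the same change on the other core: the same change on two cores in this assay, a number 1 percentage points higher (within the scatter) from compound 1 to compound 2 and a number 1 percentage points lower (within the scatter) from compound 3 to compound 4, 2 percentage points apart, within the scatter of two such steps

Likewise, 4-nitrophenyl in place of 3,4-dimethoxyphenyl gave a number 1 percentage points lower from compound 2 to compound 4 (within the scatter), which also agrees with the earlier step for that change: the same change on two cores in this assay, a number 1 percentage points higher (within the scatter) from compound 1 to compound 3 and a number 1 percentage points lower (within the scatter) from compound 2 to compound 4, 2 percentage points apart, within the scatter of two such steps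

So neither change moved the read-out clearly on either core, and nothing here separates its behaviour on one core from its behaviour on the other, but this does not prove that the cores respond alike, since a step that cannot be told from the scatter gives little to compare, and it says nothing about how a change with a clear effect would carry over.

Still open, on these data alone, is whether any group at these two places can lift the inhibition clear of the scatter, since the benzyl ring carries only chloro or fluoro and the saturated ring carbon only 4-nitrophenyl or 3,4-dimethoxyphenyl. A carboxylic acid or an amine on that aromatic ring, or a longer chain in place of the benzyl group, might read differently, and so might any of these compounds at another dose.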